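This account rests on a few compounds, and the source may have more. Where it says the series, first, only, none or still open, it means among the compounds named here.

Compound 1, `Cc1cc(N2CC[C@@H](C)[C@@H](N(C)c3ncnc4[nH]ccc34)C2)n2nc(SCC3CCCCC3)nc2n1`, was tested in a functional assay on BGC-823 cells (Homo sapiens) for inhibition, read by MTT assay, with a stated time of 72 h (a lower number here means a stronger inhibitor, a higher number a weaker inhibitor), and compound 1 gave 16300 nM. Compound 2, `Cc1cc(N2CC[C@@H](C)[C@@H](N(C)c3ncnc4[nH]ccc34)C2)n2nc(SCc3cc(Cl)ccc3Cl)nc2n1`, gave 18900 nM in this assay. Of the two numbers, compound 1 shows the lower one, yet the gap to compound 2 is within the scatter, so the two cannot be put in order. Going by the values given here, the only measured step, a 1.2-fold higher number from compound 1 to compound 2 (0.06 log units; within the scatter), touched the same part of the shared core: 2,5-dichlorophenyl in place of cyclohexyl on a saturated chain carbon bound to a sulfur.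

Compound 3, `Cc1cc(N2CC[C@@H](C)[C@@H](N(C)c3ncnc4[nH]ccc34)C2)n2nc(SCc3ccc(Cl)cc3)nc2n1`, has not yet been measured. It differs from compound 1 by 4-chlorophenyl in place of cyclohexyl on a saturated chain carbon bound to a sulfur. This is the same kind of exchange as in the measured step, with 4-chlorophenyl rather than 2,5-dichlorophenyl entering. Because the measured step of a 1.2-fold higher number from compound 1 to compound 2 (0.06 log units; within the scatter) stayed within the scatter, no movement beyond the scatter is expected here either. The step from compound 1 to compound 3 is estimated at a 1.0-fold higher number from compound 1 to compound 3 (0.02 log units; within the scatter). Compound 3 is therefore expected to give about 17000 nM in this assay, with a likely range from 7000 nM to 40000 nM.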

Compound 3, half-maximal inhibitory concentration: 26300 nM
The estimate for compound 3 lay 1.5-fold (0.19 log units) below the measured number, and the stated range covers the measured number.
By their numbers in this assay, from the lowest: compounds 1, 2 and 3 (each within the scatter of the next).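

In this assay the exchange of cyclohexyl for 4-chlorophenyl gave a 1.6-fold higher number from compound 1 to compound 3 (0.21 log units; within the scatter) and the exchange of 2,5-dichlorophenyl for 4-chlorophenyl gave a 1.4-fold higher number from compound 2 to compound 3 (0.14 log units; within the scatter) so neither step can be told apart from repeat measurement. With a third group in hand, the place on a saturated chain carbon bound to a sulfur has now carried a non-aromatic carbon ring, an aromatic ring with one chlorine and an aromatic ring with two chlorines, and the three compounds still cannot be put in order. Nothing available here bears on why these numbers lie so close together.

The compounds shown leave open whether a group of a different kind at this place, such as an amine, a carboxylic acid or a longer chain, would give a step beyond the scatter in this assay as all three carry a carbon ring there. They also leave open how the plain benzyl group, with no chlorine on its ring, would read against compound 1 and compound 3 in the same assay.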